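Adding a 1-carboxy-1-methylethyl group to the amino nitrogen

A few compounds are considered here, and "the series" means these few. Any claim that something is new, unique, unknown or untested is made for them only; others in the source may bear on it.

In a functional assay on MCF7 cells (Homo sapiens) for cytotoxicity, read by trypan blue exclusion, with a stated time of 96 h (on this read-out lower numbers stand for stronger inhibition of growth and higher numbers for weaker inhibition of growth), compound 1 `COc1cc(OC)c(/C=C/S(=O)(=O)Nc2ccc(OC)c(O)c2)c(OC)c1` gives 25 nM, while compound 2 `COc1cc(OC)c(/C=C/S(=O)(=O)Nc2ccc(OC)c(N)c2)c(OC)c1` gives 4 nM, the lower of the two numbers. Compound 3 `COc1cc(OC)c(/C=C/S(=O)(=O)Nc2ccc(OC)c(NC(C)(C)C(=O)O)c2)c(OC)c1` keeps the core of compound 2 and alters only its amino group: 1-carboxy-1-methylethyl in place of hydrogen on a nitrogen on an aromatic ring. In words, 1-carboxy-1-methylethyl takes the place of a hydrogen on a nitrogen on an aromatic ring, so amino becomes (1-carboxy-1-methylethyl)amino.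

Within the data shown here, only one measured step bears on this change: a 6.3-fold lower number from compound 1 to compound 2 (0.80 log units; beyond the scatter), where amino replaced hydroxy on an aromatic carbon. Among the measured compounds shown here, it lies beyond the scatter but is modest, and it is only an indirect guide, since no measured compound carries anything extra on this nitrogen. A step of similar size is therefore expected, and the expected direction is towards a higher number, meaning weaker growth inhibition, though this direction remains uncertain. The estimated change is a 5.0-fold higher number from compound 2 to compound 3 (0.70 log units; beyond the scatter). The expected value for compound 3 is 20 nM, within an estimated range of 4 nM to 100 nM.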

Compound 3, concentration for 50% growth inhibition: 80 nM
Beside the measured number, compound 3's estimate is 4.0-fold (0.60 log units) below it; measured number inside the range.
By their numbers in this assay, from the lowest: compound 2; then compound 1; then compound 3.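

In this assay, among these compounds, compound 3 gives the first look at anything extra on the amino nitrogen, and 1-carboxy-1-methylethyl in place of hydrogen produces a 20-fold higher number from compound 2 to compound 3 (1.30 log units; beyond the scatter) in a large step towards weaker growth inhibition. The comparison with the hydroxy compound shows a 3.2-fold higher number from compound 1 to compound 3 (0.51 log units; beyond the scatter) in a modest step, so the advantage of the free amino group over hydroxy does not survive this addition: with the new group attached, the nitrogen-linked compound falls behind the hydroxy one. Nothing in the available data accounts for this loss of growth inhibition.

A single substituent on this nitrogen cannot show whether the rise in the number follows from the size of the added group or from its carboxylic acid. A plain methyl on the nitrogen, an acetyl group, or the methyl ester of the same acid could begin to separate those two possibilities, and a longer chain ending in a carboxylic acid or an amine would show whether this nitrogen accepts other kinds of addition.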